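The compounds below may be only part of what the source reports. "The series", "measured", "known", "first", "only" and "open" are said of these compounds alone.

Measured compounds:
- Compound 1 `CCCCNc1cc(Oc2c(OC)cc3cc(C#N)ccc3c2OC)nc(Nc2ccc(C#N)cc2)n1`; in an ADME assay on MT4 cells (Homo sapiens) for cytotoxicity, read by MTT assay, with a stated time of 5 days (on this read-out higher numbers stand for lower toxicity in this test and lower numbers for higher toxicity in this test), compound 1 gives > 125000 nM, which is a limit of the test rather than a number.
- Compound 2 `COc1cc2cc(C#N)ccc2c(OC)c1Oc1cc(NC2CCCC2)nc(Nc2ccc(C#N)cc2)n1`; in this assay compound 2 gives > 125000 nM, again a limit and not a number.

Compound 2 therefore stands at the top of the range the test can report, and neither value shown gives a number. Compound 3 `COc1cc2cc(C#N)ccc2c(OC)c1Oc1cc(NCCCCO)nc(Nc2ccc(C#N)cc2)n1` differs from compound 2 by 4-hydroxybutyl in place of cyclopentyl on a nitrogen on an aromatic ring. Among the compounds with values here, the only measured step, a step that the two limits leave unreadable from compound 1 to compound 2, cannot be read as a size because of the limit of > 125000 nM in this assay, at which 2 of the 2 values shown sit. Within the data shown here, that step does bear on the present one, since both replace one small group on the same nitrogen, but it says only that neither change brought toxicity into the measurable range. The step from compound 2 to compound 3 is accordingly expected to be a number no higher from compound 2 to compound 3 (the limit leaves the size open), that is, no readable change. Compound 3 is estimated at 125000 nM, within 60000 nM to 300000 nM, most likely reported again as a limit.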

Compound 3, half-maximal cytotoxic concentration: 39100 nM
Compound 3: the middle estimate sits 3.2-fold (0.50 log units) above what was measured; measured number outside the range, below it.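

Compound 3 is the first of these compounds whose toxicity falls inside the range that this assay can report, so the group on this nitrogen can affect the read-out. Replacing the ring with the open chain gives an at least 3.1-fold lower number from compound 2 to compound 3 (0.50 log units; beyond the scatter), and adding only a hydroxy to the butyl chain gives an at least 3.1-fold lower number from compound 1 to compound 3 (0.50 log units; beyond the scatter), so in both comparisons the hydroxybutyl compound is the more toxic in this test. The step from compound 1 to compound 2 cannot be read, and the two steps just given show only a minimum size, for the same reason: the limit of > 125000 nM in this assay, at which 2 of the 3 values shown sit.

Going by these compounds, the true distance between compound 3 and the two limit compounds remains open. On these data alone, it is also open whether a shorter hydroxyalkyl chain, a methoxy, an amine or a carboxylic acid at the chain end would lower the number in the same way.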